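Methylating the Amide Nitrogen of Compound 1

A few compounds are considered here, and "the series" means these few. Any claim that something is new, unique, unknown or untested is made for them only; others in the source may bear on it.

Among the compounds with values here, compound 1 `COCc1ccc(-c2ccc3nnc(C(N)=O)c(N[C@@H](C)C4CCOCC4)c3c2)cn1` gives 5.6 uL/min in an ADME assay on cells (Hepatocyte, Rattus norvegicus) for metabolic stability, read by HPLC, with a stated time of 30 min, tested at 1 uM (on this read-out lower numbers stand for slow clearance and higher numbers for fast clearance), the lower of the two numbers measured so far. Compound 2 `COCc1ccc(-c2ccc3nnc(C(N)=O)c(N[C@@H](C)c4nn(C)cc4C)c3c2)cn1` gives 18 uL/min in this assay, and the step of a 3.2-fold higher number from compound 1 to compound 2 (0.51 log units; beyond the scatter) concerns a different part of the molecule. Compound 3 `CNC(=O)c1nnc2ccc(-c3ccc(COC)nc3)cc2c1N[C@@H](C)C1CCOCC1` differs from compound 1 by methyl in place of hydrogen on an amide-type nitrogen. Within the data shown here, no measured step touches the amide-type nitrogen, so the one known step offers no direct guide, and only a small step, if any beyond the scatter, is expected: a 1.4-fold higher number from compound 1 to compound 3 (0.15 log units; within the scatter). Compound 3 is therefore estimated at 8 uL/min, with a range from 4 uL/min to 16 uL/min.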

Compound 3, intrinsic clearance in a liver preparation (reported as CLH), per the amount of preparation that the assay uses: 5.8 uL/min
Beside the measured number, compound 3's estimate is 1.4-fold (0.14 log units) above it, within the range that was stated.
By their numbers in this assay, from the lowest: compounds 1 and 3 (each within the scatter of the next); then compound 2.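

In this assay, within the data shown here, the methyl in place of hydrogen on the amide-type nitrogen gives a 1.0-fold higher number from compound 1 to compound 3 (0.02 log units; within the scatter) and so provides the first reading at this position. The change from carbamoyl to methylcarbamoyl therefore leaves the two numbers within the scatter of each other. No measured evidence here bears on this result.

From the compounds shown here alone, whether an ethyl group or a longer chain on this nitrogen would also stay within the scatter remains open. So does whether the same methyl step would read alike with 1,4-dimethyl-1H-pyrazol-3-yl in place of oxan-4-yl.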